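Methoxy in place of hydrogen on the aryl ring of compound 1

A few compounds are considered here, and "the series" means these few. Any claim that something is new, unique, unknown or untested is made for them only; others in the source may bear on it.

Measured so far:
- compound 1, `FC(F)(F)c1ccc2[nH]c(-c3ccccc3)nc2c1`: 75.6%
- compound 2, `CN(C)c1ccc(-c2nc3cc(C(F)(F)F)ccc3[nH]2)cc1`: 30.9%

Going by the values given here, in a functional assay on aorta (Rattus norvegicus, strain Wistar) for inhibition, with a stated time of 60 min (a higher number here means a larger maximal response, a lower number a smaller maximal response), compound 1 gives 75.6%, the highest of the two numbers so far. Among the compounds with values here, compound 2 sits a long way under it: the change a number 44.7 percentage points lower from compound 1 to compound 2 (beyond the scatter), with dimethylamino in place of hydrogen on an aromatic carbon, is well beyond the scatter and is the only step recorded.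

Compound 3, `COc1ccccc1-c1nc2cc(C(F)(F)F)ccc2[nH]1`, is not yet measured. It differs from compound 1 by methoxy in place of hydrogen on an aromatic carbon; the new group sits on an aromatic carbon of the six-membered carbon-only ring, ortho to a large group.

The step from compound 1 to compound 2 bears on this only loosely: it replaces the same hydrogen class on the same ring, but with a different group and at a different place, and it was large. Within the data shown here, no measured step involves methoxy or this position. A drop in this assay is therefore plausible but far from certain, and a change within the scatter cannot be excluded.

On balance compound 3 is expected to give 62% (range 40% to 85%), i.e. an expected step of a number 13.6 percentage points lower from compound 1 to compound 3 (beyond the scatter).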

Compound 3, largest response reached (Emax), in percent of the reference or control that the assay uses: 45.7%
Beside the measured number, compound 3's estimate is 16.3 percentage points above it, within the range that was stated.
By their numbers in this assay, from the lowest: compound 2; then compound 3; then compound 1.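

In this assay, methoxy in place of hydrogen on an aromatic carbon, ortho to a large group, gives a number 29.9 percentage points lower from compound 1 to compound 3 (beyond the scatter), so this place on the ring of compound 1 is shown to be sensitive to substitution, something the earlier pair could not show. Set beside a number 44.7 percentage points lower from compound 1 to compound 2 (beyond the scatter), this gives two separate hydrogen replacements on this ring, both ending beyond the scatter under compound 1, and neither of the substituted compounds goes against that within this small set. Nothing available bears on the reason for the lower number at this place.

Going by these compounds, whether the drop belongs to methoxy itself or to the place remains open: a fluorine atom or a longer ethoxy chain at the same place, or methoxy on another aromatic carbon of that ring, would separate the two. Equally open, on these data alone, is whether an amine or a carboxylic acid at this place would take the number in this assay lower still or bring it back towards that of compound 1.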